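The source may report more compounds than this note shows. Statements on the series, on what has been measured and on what is new or still open speak of the compounds shown alone.

Compound 1 `COc1ccc(O)c(C(=O)N2CCC(=CC(=O)N[C@@H]3CCN(Cc4ccc5cc(F)ccc5c4)C3)CC2)c1`: 119 mL/min/kg
Compound 2 `COc1cccc(C(=O)N2CCC(=CC(=O)N[C@@H]3CCN(Cc4ccc5cc(F)ccc5c4)C3)CC2)c1O`: 162 mL/min/kg

For the measured compounds named here, in an in vitro ADME assay on microsomes from liver (Homo sapiens) for metabolic stability (a higher number here means faster removal of the compound, a lower number slower removal), the only measured step is a 1.4-fold higher number from compound 1 to compound 2 (0.13 log units; within the scatter). Compound 2 therefore has a single neighbour on the scale, and the two numbers cannot be told apart.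

The next compound is compound 3 `O=C(C=C1CCN(C(=O)c2ccc(Cl)cc2O)CC1)N[C@@H]1CCN(Cc2ccc3cc(F)ccc3c2)C1`, still unmeasured. The change is 4-chloro-2-hydroxyphenyl in place of 2-hydroxy-3-methoxyphenyl on a carbonyl carbon. The rest of the molecule stays the same, so the question is what this one group does to the number.

The evidence is thin. Going by the values given here, the one measured step swaps one hydroxy-methoxy group for another, and its size stayed inside the scatter. Among the compounds with values here, no measured pair replaces a methoxy group with a chlorine, so the data do not show this change directly. With nothing pointing firmly either way, the expectation rests on the values of compound 1 at 119 mL/min/kg and compound 2 at 162 mL/min/kg, and no step beyond the scatter is expected. The estimated step is a 1.3-fold lower number from compound 2 to compound 3 (0.11 log units; within the scatter). For compound 3 the expected value is 125 mL/min/kg, with an estimated range from 60 mL/min/kg to 230 mL/min/kg.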

Compound 3, clearance: 87 mL/min/kg
The estimate for compound 3 lay 1.4-fold (0.16 log units) above the measured number; low and high end bracket the measured number.
By their numbers in this assay, from the lowest: compounds 3, 1 and 2 (each within the scatter of the next).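

In this assay, the measured pairs now include a change at this position, on a carbonyl carbon whose other neighbour is an amide-type nitrogen in a ring, in which the methoxy group is absent and a chlorine is present: a 1.9-fold lower number from compound 2 to compound 3 (0.27 log units; within the scatter) is what 4-chloro-2-hydroxyphenyl gives in place of 2-hydroxy-3-methoxyphenyl. The comparison with the other methoxy-bearing group reads a 1.4-fold lower number from compound 1 to compound 3 (0.14 log units; within the scatter), so neither pair separates 4-chloro-2-hydroxyphenyl from the two hydroxy-methoxy groups, even though all three compounds carry a hydroxy group on the aromatic ring and differ in what else it bears. No measurement available here offers an explanation for these numbers.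

The three compounds leave open what happens at this position without the hydroxy group, as with a plain phenyl, or with a different substituent on the ring, such as an amine or a carboxylic acid. They also leave open whether any group placed here can move the number in this assay by more than the scatter, or whether changes elsewhere in the shared core would be needed to do so.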